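Swapping phenyl for 2,6-dichlorophenyl on compound 1

The source may report more compounds than this note shows. Statements on the series, on what has been measured and on what is new or still open speak of the compounds shown alone.

- compound 1 `COc1ccc(/C=C2\CCC/C(=C\c3ccccc3)C2=O)cc1`: 291000 nM
- compound 2 `COc1ccc(/C=C2\CCC/C(=C\c3ccc(N(C)C)cc3)C2=O)cc1`: 392000 nM
- compound 3 `COc1ccc(/C=C2\CCC/C(=C\c3ccc([N+](=O)[O-])cc3)C2=O)cc1`: 435000 nM

In an ADME assay on Vero cells (Chlorocebus sabaeus) for inhibition (a lower number here means that less compound is tolerated, a higher number that more compound is tolerated), compound 1 cannot be told apart from its two relatives. The measured steps are small: a 1.3-fold higher number from compound 1 to compound 2 (0.13 log units; within the scatter) for dimethylamino in place of hydrogen on an aromatic carbon, and a 1.5-fold higher number from compound 1 to compound 3 (0.17 log units; within the scatter) for nitro in place of hydrogen on an aromatic carbon. Compound 4 `COc1ccc(/C=C2\CCC/C(=C\c3c(Cl)cccc3Cl)C2=O)cc1` differs from compound 1 as follows: 2,6-dichlorophenyl in place of phenyl on a double-bonded chain carbon bound to a double-bonded ring carbon. For the measured compounds named here, no measured compound carries chlorine, so these steps offer only indirect guidance. With both inside the scatter, no step beyond it is expected in this assay. The expected step is a 1.0-fold higher number from compound 1 to compound 4 (0.01 log units; within the scatter). For compound 4 the estimate is 300000 nM, with an expected range from 130000 nM to 600000 nM.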

Compound 4, half-maximal cytotoxic concentration: 232000 nM
Compound 4: middle estimate off by 1.3-fold (0.11 log units), on the high side; the range from low to high includes it.
By their numbers in this assay, from the lowest: compounds 4, 1, 2 and 3 (each within the scatter of the next).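

Placing 2,6-dichlorophenyl on a double-bonded chain carbon bound to a double-bonded ring carbon gives a 1.3-fold lower number from compound 1 to compound 4 (0.10 log units; within the scatter) in this assay for the half-maximal cytotoxic concentration. The earlier compounds shown here showed only single groups replacing hydrogen on the aromatic ring, whereas this change brings chlorine into the series and still gives no difference that can be read beyond the scatter. No measurement here offers an explanation for this result.

On these data alone, whether a carboxylic acid on this aromatic ring would give a step beyond the scatter remains open. The same question stands for a longer chain in place of phenyl.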